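This account rests on a few compounds, and the source may have more. Where it says the series, first, only, none or still open, it means among the compounds named here.

Working notes on the amide series

The shared core carries an amide whose carbonyl-side aryl is varied. Compound 1 `O=C(Nc1cccc(-c2oc3cc(-c4ccc(F)cc4)ccc3c(=O)c2O)c1)c1ccccc1F` gives 10800 nM in a functional assay on HCC1937 cells (Homo sapiens) for antiproliferative activity, read by CCK-8 assay, with a stated time of 72 h; on this read-out higher numbers stand for weaker inhibition and lower numbers for stronger inhibition. Compound 2 `CCc1ccc(C(=O)Nc2cccc(-c3oc4cc(-c5ccc(F)cc5)ccc4c(=O)c3O)c2)cc1` gives 13200 nM in this assay, and the pair shows a 1.2-fold higher number from compound 1 to compound 2 (0.09 log units; within the scatter). Compound 3 `Cc1cc(C)cc(C(=O)Nc2cccc(-c3oc4cc(-c5ccc(F)cc5)ccc4c(=O)c3O)c2)c1` gives 4860 nM, the lowest of the three numbers; its steps are a 2.2-fold lower number from compound 1 to compound 3 (0.35 log units; beyond the scatter) and a 2.7-fold lower number from compound 2 to compound 3 (0.43 log units; beyond the scatter), both modest but beyond the scatter, so compound 3 stands as the strongest inhibitor of those measured.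

Compound 4 `O=C(Nc1cccc(-c2oc3cc(-c4ccc(F)cc4)ccc3c(=O)c2O)c1)c1ccc(-c2ccccc2)cc1` has not been measured. It differs from compound 3 by 4-phenylphenyl in place of 3,5-dimethylphenyl on a carbonyl carbon. The measured steps bear on this only loosely: each swap of the aryl on the carbonyl carbon moved the number by a modest amount, and 3,5-dimethylphenyl gave the lowest number, so the change to 4-phenylphenyl is expected to move back toward the numbers of compound 1 and compound 2, by a step of about a 1.9-fold higher number from compound 3 to compound 4 (0.27 log units; within the scatter). Compound 4 is therefore estimated at 9000 nM in this assay, with a range from 3500 nM to 25000 nM.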

Compound 4, half-maximal inhibitory concentration: 44100 nM
Compound 4: middle estimate off by 4.9-fold (0.69 log units), on the low side; measured number outside the range, above it.
By their numbers in this assay, from the lowest: compound 3; then compounds 1 and 2 (each within the scatter of the next); then compound 4.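

Working from the numbers in this assay, 4-phenylphenyl on a carbonyl carbon whose other neighbour is an amide-type nitrogen gives the highest number so far, with a 9.1-fold higher number from compound 3 to compound 4 (0.96 log units; beyond the scatter) and a 4.1-fold higher number from compound 1 to compound 4 (0.61 log units; beyond the scatter) as its steps from the two other aryl groups. The closest pair isolates the outer group, since phenyl in place of ethyl on an aromatic carbon gives a 3.3-fold higher number from compound 2 to compound 4 (0.52 log units; beyond the scatter), so this position responds to more than the change among the three earlier aryl groups, whose widest step was a 2.7-fold lower number from compound 2 to compound 3 (0.43 log units; beyond the scatter). No measured evidence here accounts for the rise.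

The compounds shown leave open how the number responds to a pyridine ring in place of the added phenyl, or to an amine or a carboxylic acid on the aryl. They also leave open whether a single methyl group would keep the number of compound 3.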